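A few compounds are considered here, and "the series" means these few. Any claim that something is new, unique, unknown or untested is made for them only; others in the source may bear on it.

Compound 1 `Cc1cc(-c2ccnc(Nc3ccc(N(C)C)cc3)n2)c(C)o1` is examined in a functional assay for inhibition, with Homo sapiens as the target (on this read-out lower numbers stand for stronger inhibition and higher numbers for weaker inhibition), where compound 1 gives 4900 nM. Among the three measured compounds it gives the highest number. Its nearest neighbour is compound 2 `CN(C)c1ccc(Nc2nccc(-c3ccsc3)n2)cc1`, which in this assay gives 2100 nM; the step of a 2.3-fold lower number from compound 1 to compound 2 (0.37 log units; beyond the scatter) comes from putting thiophen-3-yl in place of 2,5-dimethylfuran-3-yl on an aromatic carbon. Furthest away is compound 3 `CN(C)c1ccc(Nc2nccc(-c3cccs3)n2)cc1`, which gives 900 nM; the step of a 5.4-fold lower number from compound 1 to compound 3 (0.74 log units; beyond the scatter) comes from thiophen-2-yl in place of 2,5-dimethylfuran-3-yl, and the step of a 2.3-fold lower number from compound 2 to compound 3 (0.37 log units; beyond the scatter) from thiophen-2-yl in place of thiophen-3-yl.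

Compound 4 `Cc1cc(-c2ccnc(Nc3ccccc3)n2)c(C)o1` differs from compound 1 in a different part of the molecule: hydrogen in place of dimethylamino on an aromatic carbon, on an aromatic carbon of a six-membered aromatic ring of carbon only, para to a large group. For the measured compounds named here, no measured step touches this position; all three measured steps change only the five-membered ring on the other side of the shared core, and each of them was modest. There is thus no direct guide for the size or direction of the step. Compound 4 is estimated at 8000 nM, within a range from 2000 nM to 30000 nM, which would mean an expected step of a 1.6-fold higher number from compound 1 to compound 4 (0.21 log units; within the scatter).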

Compound 4, half-maximal inhibitory concentration: 2000 nM
For compound 4 the middle estimate is 4.0-fold (0.60 log units) above the measured one; measured number inside the range.
By their numbers in this assay, from the lowest: compound 3; then compounds 4 and 2 (each within the scatter of the next); then compound 1.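

For the compounds shown here, this is the first measured change on the six-membered carbon ring, away from the five-membered ring varied so far. In this assay replacing dimethylamino with hydrogen gives a 2.5-fold lower number from compound 1 to compound 4 (0.39 log units; beyond the scatter), so at this position the change strengthens inhibition, and on the shared core of compound 1 dimethylamino is not needed for inhibition to be seen. Nothing at hand explains this modest gain.

With a single pair at this position, the step may not carry over to the thiophen-2-yl partner of compound 3, which carries dimethylamino and has no hydrogen counterpart among these compounds. Going by these compounds, it also stays open how other groups in this place, such as a methoxy group, a primary amine or a carboxylic acid, would compare with hydrogen and dimethylamino.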